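Hydrolytic stability of the bis(trifluoromethyl)phenyl series: nitrile analogue

This account rests on a few compounds, and the source may have more. Where it says the series, first, only, none or still open, it means among the compounds named here.

Measured so far:
compound 1, `C=CC(=O)Nc1cc(C(F)(F)F)cc(C(F)(F)F)c1`, 6.1 h
compound 2, `C=CC(=O)Oc1cc(C(F)(F)F)cc(C(F)(F)F)c1`, < 0.017 h
compound 3, `C=Cc1cc(C(F)(F)F)cc(C(F)(F)F)c1`, > 50 h

In an ADME assay for pharmacokinetics, read by LC-MS, in phosphate buffer, with a stated time of 72 h, at pH 7.4, tested at 250 uM (on this read-out lower numbers stand for a shorter-lived compound and higher numbers for a longer-lived compound), compound 2 gives only a limit, < 0.017 h, sitting at the limit of < 0.017 h in this assay, at which 1 of the 3 values shown sits. Compound 3 also gives only a limit, at the limit of > 50 h in this assay, at which 1 of the 3 values shown sits. Compound 1 gives a number, 6.1 h. The steps of an at least 350-fold lower number from compound 1 to compound 2 (2.55 log units; beyond the scatter) and an at least 2900-fold higher number from compound 2 to compound 3 (3.46 log units; beyond the scatter) place compound 2 as the shortest-lived of the three.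

Compound 4, `N#Cc1cc(C(F)(F)F)cc(C(F)(F)F)c1`, differs from compound 2 by cyano in place of (vinylcarbonyl)oxy on an aromatic carbon. The step of an at least 2900-fold higher number from compound 2 to compound 3 (3.46 log units; beyond the scatter), which removes the same leaving group, is the one that bears most directly; the step of an at least 8.1-fold higher number from compound 1 to compound 3 (0.91 log units; beyond the scatter) points the same way. A large upward step in this assay is therefore expected, most likely ending at the upper limit. Compound 4 is expected to give about 50 h, within 20 h to 200 h. The expected step is an at least 2900-fold higher number from compound 2 to compound 4 (3.46 log units; beyond the scatter).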

Compound 4, half-life: 50 h
Beside the measured number, compound 4's estimate shows no gap at the digits printed; low and high end bracket the measured number.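

With cyano in place of (vinylcarbonyl)oxy on this aromatic carbon, the half-life in this assay rises: an at least 2900-fold higher number from compound 2 to compound 4 (3.46 log units; beyond the scatter). Cyano in place of (vinylcarbonyl)amino also lengthens it, an 8.2-fold higher number from compound 1 to compound 4 (0.91 log units; beyond the scatter), so a long half-life at this position is not confined to the vinyl group of compound 3. Compound 3 gives only a limit, > 50 h. The size of the remaining step cannot be read: a number no higher from compound 3 to compound 4 (the limit leaves the size open).

Open, from the compounds shown here alone, is whether a carboxylic acid, an amine or a longer chain on this aromatic carbon would give a half-life of this order. Also open, going by these compounds, is how the half-life would shift with a methoxy group in place of either trifluoromethyl group.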